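Notes on the step from compound 3 to compound 4

A few compounds are considered here, and "the series" means these few. Any claim that something is new, unique, unknown or untested is made for them only; others in the source may bear on it.

The series shares one core and varies in its chain, read in an ADME assay on Vero cells (Chlorocebus sabaeus) for cytotoxicity, read by MTT assay; a higher number here means a weaker inhibitor, a lower number a stronger inhibitor. Compound 1 (`CCCCCCCC(=O)OCC(C)(C)CC1=C(O)C(=O)c2ccccc2C1=O`) reads > 258000 nM and this is a limit, not a number. Compound 2 (`CCCCCCCCC(=O)OCC(C)(C)CC1=C(O)C(=O)c2ccccc2C1=O`) gives a measured number (150000 nM). Compound 3 (`CCCCCCCCCC(=O)OCC(C)(C)CC1=C(O)C(=O)c2ccccc2C1=O`) gives 203000 nM and stands within the scatter of compound 2, its nearest number.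

Compound 4 (`CCCCCCCCCCC(=O)OCC(C)(C)CC1=C(O)C(=O)c2ccccc2C1=O`) differs from compound 3 by methyl in place of hydrogen on a saturated chain carbon, nine bonds along the chain from a carbonyl carbon with methyl in place of hydrogen on a saturated chain carbon, nine bonds along the chain from a carbonyl carbon. Among the measured compounds shown here, the closest precedent is the same kind of change eight bonds along the chain (a 1.4-fold higher number from compound 2 to compound 3 (0.13 log units; within the scatter)). The two steps out of compound 1 give only floors (an at least 1.7-fold lower number from compound 1 to compound 2 (0.23 log units; that floor lies within the scatter); an at least 1.2-fold lower number from compound 1 to compound 3 (0.10 log units; that floor lies within the scatter)). None of these steps shows a change beyond the scatter, so no step beyond the scatter is expected in this assay.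

The expected step is small (a 1.2-fold lower number from compound 3 to compound 4 (0.06 log units; within the scatter)). For compound 4 the estimated value is 175000 nM (expected range 90000 nM to 300000 nM).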

Compound 4, half-maximal inhibitory concentration: > 233000 nM
Compound 4: a limit, no number; the forecaster's own chance of this, stated with the estimate: 15%; at least 1.3-fold (0.12 log units) between middle value and limit.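

In this assay compound 4 gives a limit and not a number (> 233000 nM). Both readable steps are floors that lie within the scatter (an at least 1.1-fold higher number from compound 3 to compound 4 (0.05 log units; that floor lies within the scatter); an at least 1.5-fold higher number from compound 2 to compound 4 (0.19 log units; that floor lies within the scatter)), so methyl on a saturated chain carbon, nine bonds along the chain from a carbonyl carbon, shows no change beyond the scatter and adds no new measured number to the series. The step from compound 1 to compound 4 cannot be read, since both ends are limits.

Only compound 2 and compound 3 give measured numbers, and these lie within the scatter of each other, so no dependence on chain length can be read from the compounds shown. Going by these compounds, whether a longer chain would return a measured number in this assay stays open, as does the reading of an amine or a carboxylic acid in place of this methyl.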